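This account rests on a few compounds, and the source may have more. Where it says the series, first, only, none or still open, it means among the compounds named here.

Measured so far in a functional assay on SUP-B15 cells (Homo sapiens) for antiproliferative activity, with a stated time of 72 h; a lower number here means that less compound is needed, a higher number that more compound is needed for the effect:
compound 1 `COc1ccc(-c2c(I)c(=O)c3c(OC)cc(OC)cc3n2S(=O)(=O)c2ccc(OC)cc2)cc1` — 12300 nM
compound 2 `COc1ccc(-c2cc(=O)c3c(OC)cc(OC)cc3n2S(=O)(=O)c2ccc(C=O)cc2)cc1` — > 34400 nM; this is a limit of the assay, not a number

Compound 2 therefore stands at the top edge of what this assay reports, as the limit of > 34400 nM in this assay, at which 1 of the 2 values shown sits, records. Going by the values given here, compound 1 and compound 2 differ from each other in two places, so no single step joins them; their two values show only that compound 1 gives a number while compound 2 gives none. The next compound, compound 3 `COc1ccc(-c2cc(=O)c3c(OC)cc(OC)cc3n2S(=O)(=O)Cc2ccccc2)cc1`, changes compound 2 in one place: benzyl in place of 4-formylphenyl on a sulfonyl sulfur. Among the compounds with values here, no measured step bears on this change, so the direction is open; with both readings weak, any step in this assay is expected to be no larger than modest, in either direction, and may fall within the scatter. Compound 3 is expected near 25000 nM, within 8000 nM to 80000 nM. The step from compound 2 to compound 3 that this estimate implies is an at least 1.3-fold lower number from compound 2 to compound 3 (0.13 log units; that floor lies within the scatter), an expectation only.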

Compound 3, half-maximal effective concentration: > 34400 nM
Compound 3 ended at the assay's limit (the forecaster's own chance of this, stated with the estimate: 45%); at least 1.3-fold (0.13 log units) between middle value and limit.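

No step can be read from compound 2 to compound 3, because each gives only a limit of the assay and not a number: the limit of > 34400 nM in this assay, at which 2 of the 3 values shown sit. As far as these compounds go, whether benzyl or 4-formylphenyl on a sulfonyl sulfur gives the lower number stays open.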